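A few compounds are considered here, and "the series" means these few. Any claim that something is new, unique, unknown or untested is made for them only; others in the source may bear on it.

Measured so far in a functional assay on WM793 cells (Homo sapiens) for antiproliferative activity, read by MTT assay, with a stated time of 72 h; a higher number here means a weaker inhibitor of growth, a lower number a stronger inhibitor of growth:
Compound 1 `Cc1c(C(=O)Nc2ccc(SC#N)cc2)nnn1-c1ccc(C(C)C)cc1`: > 100000 nM
Compound 2 `Cc1ccc(Cl)cc1-n1nnc(C(=O)Nc2ccc(SC#N)cc2)c1C`: 72800 nM

Compound 1 gives only a limit of the assay and not a number: the limit of > 100000 nM in this assay, at which 1 of the 2 values shown sits. Among the measured compounds shown here, that leaves compound 2, at 72800 nM, with the only true number so far, so there is little to rank it against.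

The next compound, compound 3 `Cc1ccc(Cl)c(-n2nnc(C(=O)Nc3ccc(SC#N)cc3)c2C)c1`, has the same atoms as compound 2, joined differently: 2-chloro-5-methylphenyl in place of 5-chloro-2-methylphenyl on an aromatic nitrogen. For the measured compounds named here, one measured step bears on this, since it changes the group at the same aromatic nitrogen: an at least 1.3-fold lower number from compound 1 to compound 2 (0.13 log units; that floor lies within the scatter). That step starts from a limit, so it offers a floor rather than a true size. It also involves a different pair of groups from the one exchanged here.

With so little to go on, the estimate stays anchored on compound 2 at 72800 nM. No change beyond the scatter is expected in this assay, in either direction, and the expected step is a 1.1-fold lower number from compound 2 to compound 3 (0.05 log units; within the scatter). An outcome reported only as a limit also remains possible. Compound 3 is expected at 65000 nM, with an estimated range of 25000 nM to 100000 nM.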

Compound 3, concentration for 50% growth inhibition: > 100000 nM
Compound 3 was reported as a limit (the forecaster's own chance of this, stated with the estimate: 25%); at least 1.5-fold (0.18 log units) between middle value and limit.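

In this assay, placing 2-chloro-5-methylphenyl in place of 5-chloro-2-methylphenyl on the aromatic nitrogen, with the same atoms joined differently, gives an at least 1.3-fold higher number from compound 2 to compound 3 (0.13 log units; that floor lies within the scatter). This floor does not put the two arrangements in order, but it does show that keeping the chlorine and methyl while rearranging them does not bring a second true number at this position, and that most of the series now rests on limits: the limit of > 100000 nM in this assay, at which 2 of the 3 values shown sit. The step between compound 1 and compound 3 cannot be read, since both values are limits.

Going by these compounds, how far compound 3 really lies from compound 2 remains open, so the data cannot yet say whether the arrangement of chlorine and methyl on this ring matters at all. Also open, on these data alone, is whether a different group on this aromatic nitrogen, such as a plain phenyl or a phenyl carrying an amine or a carboxylic acid, would give a number clearly lower than that of compound 2, at 72800 nM.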